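Swapping the acyl chain for a chlorophenyl group

This account rests on a few compounds, and the source may have more. Where it says the series, first, only, none or still open, it means among the compounds named here.

Measured so far:
compound 1, `CCCCCCCCC(=O)N1c2ccccc2CCC1C(=O)Nc1ccccc1C(F)(F)F` — 3350 nM
compound 2, `CCCCCCCCC(=O)N1c2ccccc2CCC1C(=O)Nc1ccccc1O` — 54300 nM

Of the compounds shown here, two have been measured in a functional assay on MDA-MB-231 cells (Homo sapiens) for cytotoxicity, read by sulforhodamine B assay, with a stated time of 72 h; on this read-out lower numbers stand for stronger inhibition of growth and higher numbers for weaker inhibition of growth. Compound 1, `CCCCCCCCC(=O)N1c2ccccc2CCC1C(=O)Nc1ccccc1C(F)(F)F`, gives 3350 nM. Among the compounds with values here, compound 2, `CCCCCCCCC(=O)N1c2ccccc2CCC1C(=O)Nc1ccccc1O`, gives 54300 nM, the highest of the two numbers; its nearest neighbour is compound 1, and the single measured step, a 16-fold higher number from compound 1 to compound 2 (1.21 log units; beyond the scatter), describes that gap.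

The next compound, compound 3, `O=C(Nc1ccccc1O)C1CCc2ccccc2N1C(=O)c1ccc(Cl)cc1`, keeps the hydroxy-bearing part of compound 2 and changes the group on the other carbonyl: 4-chlorophenyl in place of octyl on a carbonyl carbon.

Within the data shown here, the only measured step concerns a different place on the molecule, the group on the aromatic carbon, and so says nothing about how exchanging the chain on the carbonyl carbon will behave. Among the measured compounds shown here, no step that bears on this change is available. The expectation therefore rests on compound 2 alone, with a wide range: the estimated step of a 1.1-fold lower number from compound 2 to compound 3 (0.04 log units; within the scatter) means no movement beyond the scatter. Compound 3 is estimated at 50000 nM, with a range from 8000 nM to 250000 nM.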

Compound 3, concentration for 50% growth inhibition: 19600 nM
The estimate for compound 3 lay 2.6-fold (0.41 log units) above the measured number; low and high end bracket the measured number.
By their numbers in this assay, from the lowest: compound 1; then compound 3; then compound 2.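

In this assay, exchanging octyl for 4-chlorophenyl on the carbonyl carbon, while the hydroxy-bearing part stays the same, gives a 2.8-fold lower number from compound 2 to compound 3 (0.44 log units; beyond the scatter) and so a modest gain in growth inhibition. Within the data shown here, the earlier step concerned only the group on the aromatic carbon, so this is the first sign that the group on this carbonyl also moves the number, and that a long chain without a ring is not needed there, since a six-membered aromatic ring carrying chlorine does somewhat better in this pair. No measurement at hand explains this step.

The compounds shown leave open whether the ring or the chlorine accounts for the step, a question that a plain phenyl or a 4-fluorophenyl group on the same carbonyl could help to settle, and how a shorter chain such as butyl would compare with octyl. They also leave open whether the same exchange would give a step of similar size with trifluoromethyl instead of hydroxy on the aromatic carbon.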